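Aryl urea variation on the shared core

The source may report more compounds than this note shows. Statements on the series, on what has been measured and on what is new or still open speak of the compounds shown alone.

Measured so far in a functional assay on T47D cells (Homo sapiens) for inhibition, read by sulforhodamine B assay, with a stated time of 48 h; a higher number here means a weaker inhibitor of growth, a lower number a stronger inhibitor of growth:
compound 1 `COc1cc(-c2nn(-c3cccc(NC(=O)c4cccc(C(F)(F)F)c4)c3)cc2-c2ccncc2)ccc1Cl`: 2550 nM
compound 2 `COc1cc(-c2nn(-c3cccc(NC(=O)Nc4ccc(Cl)c(Cl)c4)c3)cc2-c2ccncc2)ccc1Cl`: 1420 nM

Compound 2 holds the lowest of the two numbers in this assay; its nearest neighbour is compound 1, separated by a 1.8-fold lower number from compound 1 to compound 2 (0.25 log units; within the scatter), a gap within the scatter. Compound 3 `COc1cc(-c2nn(-c3cccc(NC(=O)Nc4cccc(C(F)(F)F)c4)c3)cc2-c2ccncc2)ccc1Cl` differs from compound 2 by 3-(trifluoromethyl)phenyl in place of 3,4-dichlorophenyl on an amide-type nitrogen. For the measured compounds named here, the only measured step, a 1.8-fold lower number from compound 1 to compound 2 (0.25 log units; within the scatter), joins this aryl exchange with a change at the carbonyl, so it bears on the present step only indirectly, and it stayed within the scatter. No shift beyond the scatter is therefore expected for compound 3, estimated at 1800 nM, range 700 nM to 4500 nM. That estimate for compound 3 means a 1.3-fold higher number from compound 2 to compound 3 (0.10 log units; within the scatter).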

Compound 3, concentration for 50% growth inhibition: 1650 nM
Beside the measured number, compound 3's estimate is 1.1-fold (0.04 log units) above it; the measured number falls inside the stated range.
By their numbers in this assay, from the lowest: compounds 2, 3 and 1 (each within the scatter of the next).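

On the amide-type nitrogen, 3-(trifluoromethyl)phenyl and 3,4-dichlorophenyl cannot be told apart in this assay: a 1.2-fold higher number from compound 2 to compound 3 (0.07 log units; within the scatter). With 3-(trifluoromethyl)phenyl held constant, the change at the carbonyl carbon can now be read alone, and it also gives no separation: a 1.5-fold lower number from compound 1 to compound 3 (0.19 log units; within the scatter). No evidence is available to explain either step. Still open, going by these compounds, is whether a cyclohexyl group on that nitrogen, or a carboxylic acid on its aryl ring, would move the number beyond the scatter.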